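The compounds below may be only part of what the source reports. "The series", "measured", "known", "first", "only" and "open" are said of these compounds alone.

Measured in an ADME assay on HEK293 cells (Homo sapiens) for cytotoxicity, read by CCK-8 assay, with a stated time of 48 h; on this read-out higher numbers stand for weaker inhibition and lower numbers for stronger inhibition:
- Compound 1 `COc1ccc(/C=C\c2cc(OC)c(OC)c(OC)c2)cc1OCc1ccc(CN2CCCC[C@@H]2C(=O)O)cc1`: 42000 nM
- Compound 2 `COc1ccc(/C=C\c2cc(OC)c(OC)c(OC)c2)cc1OCc1ccc(CN2CC(C(=O)O)C2)cc1`: > 50000 nM (a limit of the assay, not a number)
- Compound 3 `COc1ccc(/C=C\c2cc(OC)c(OC)c(OC)c2)cc1OCc1ccc(CNCCN(C)C)cc1`: 39000 nM

These three share one core and differ only in the group on a saturated chain carbon bound to an aromatic carbon. Among the measured compounds shown here, compound 3 and compound 1 lie within the scatter of each other, and they are the only two with true numbers.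

Compound 4 `COc1ccc(/C=C\c2cc(OC)c(OC)c(OC)c2)cc1OCc1ccc(CN[C@H](C(=O)O)[C@@H](C)O)cc1` differs from compound 3 in one place: 1-carboxy-2-hydroxypropyl in place of 2-(dimethylamino)ethyl on an amine nitrogen. The side chain of compound 3 therefore gives way to one carrying a carboxy group, a feature also found in compound 1 and compound 2.

For the measured compounds named here, the most useful guide is the one measured swap with both ends as true numbers, which gave a 1.1-fold lower number from compound 1 to compound 3 (0.03 log units; within the scatter). As far as these compounds go, two other swaps gave an at least 1.2-fold lower number from compound 2 to compound 3 (0.10 log units; that floor lies within the scatter) and an at least 1.1-fold higher number from compound 1 to compound 2 (0.07 log units; that floor lies within the scatter), but both rest on a limit, so their true size remains open. On this evidence, no step beyond the scatter is expected in this assay. The expected step is a 1.2-fold higher number from compound 3 to compound 4 (0.06 log units; within the scatter). The result may also arrive only as a limit, the relevant one being (the limit of > 50000 nM in this assay, at which 1 of the 3 values shown sits). For compound 4, the estimate is 45000 nM, with an expected range of 27000 nM to 75000 nM.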

Compound 4, half-maximal inhibitory concentration: > 50000 nM
Compound 4: no number, only a limit (the forecaster's own chance of this, stated with the estimate: 45%); middle value at least 1.1-fold (0.04 log units) away from the limit.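

In this assay compound 4 gives > 50000 nM, which is a limit of the assay and not a number. Putting 1-carboxy-2-hydroxypropyl in place of 2-(dimethylamino)ethyl on the amine nitrogen gives an at least 1.2-fold higher number from compound 3 to compound 4 (0.10 log units; that floor lies within the scatter), and the wider comparison with the carboxy-bearing ring of the earlier series gives an at least 1.1-fold higher number from compound 1 to compound 4 (0.07 log units; that floor lies within the scatter), so this open-chain group, with its two defined stereocentres, shows no change beyond the scatter from either neighbour. Compound 2 and compound 4 both end at the limit, so the step between them cannot be read, and this ceiling now covers a second side group as well as the first: the limit of > 50000 nM in this assay, at which 2 of the 4 values shown sit.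

The compounds shown leave open how far compound 2 and compound 4 really lie from each other and from the two compounds with true numbers, since a limit hides the size of every step that touches it. They also leave open whether the carboxy or the hydroxy part of the new group matters, a question that a carboxymethyl or a 2-hydroxyethyl chain on the same amine nitrogen could help to separate.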